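The compounds below may be only part of what the source reports. "The series", "measured", "known", "first", "only" and "open" are said of these compounds alone.

Compound 1, `FC(F)(F)c1cc(/N=N/Nc2ccc(Cl)c(C(F)(F)F)c2)ccc1Cl`: 58400 nM
Compound 2, `CC(=O)N(/N=N/c1ccc([N+](=O)[O-])cc1)c1ccc([N+](=O)[O-])cc1`: 63000 nM
Compound 3, `CC(=O)N(/N=N/c1ccc([N+](=O)[O-])cc1Br)c1ccc([N+](=O)[O-])cc1Br`: 550 nM

All three were tested in a functional assay on HeLa cells (Homo sapiens) for cytotoxicity, read by MTT assay, with a stated time of 72 h; on this read-out lower numbers stand for stronger inhibition and higher numbers for weaker inhibition. Compound 3 has the lowest number of the three, and both compound 1 and compound 2 sit far above it, well beyond the usual scatter. Compound 4, `O=C(c1ccc(F)cc1)N(/N=N/c1ccc([N+](=O)[O-])cc1Br)c1ccc([N+](=O)[O-])cc1Br`, has not yet been measured. It differs from compound 3 in one place: 4-fluorophenyl in place of methyl on a carbonyl carbon, so the acetyl becomes a (4-fluorophenyl)carbonyl. Going by the values given here, no measured pair shows a change of this kind, so there is nothing to gauge it against. The step expected here, a 1.3-fold higher number from compound 3 to compound 4 (0.10 log units; within the scatter), is small, with no clear direction beyond the scatter. Compound 4 is therefore estimated at 700 nM, in a range from 150 nM to 3500 nM.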

Compound 4, half-maximal inhibitory concentration: 580 nM
Beside the measured number, compound 4's estimate is 1.2-fold (0.08 log units) above it; measured number inside the range.
By their numbers in this assay, from the lowest: compounds 3 and 4 (each within the scatter of the next); then compounds 1 and 2 (each within the scatter of the next).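

In this assay, placing 4-fluorophenyl on the carbonyl carbon instead of methyl gives a 1.1-fold higher number from compound 3 to compound 4 (0.02 log units; within the scatter), a step within the scatter. On this core, then, this position can carry a whole aromatic ring in place of a single methyl with no measurable change in the number. No available evidence explains this result. Going by these compounds, it remains open whether a plain phenyl, a longer alkyl chain or an amine on the same carbonyl carbon would also leave the number unchanged. Whether the same swap would give the same result on the core of compound 2, which has no bromine, is also unknown.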